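The source may hold more compounds than are shown below. What is called first, only, known or untested is meant among the compounds shown, and "the series" means these compounds.

In a functional assay on HeLa cells (Homo sapiens) for inhibition, read by MTT assay, with a stated time of 72 h (on this read-out lower numbers stand for stronger inhibition and higher numbers for weaker inhibition), compound 2 `COc1cc(/C=C/C(=O)c2c(O)cc(O)cc2OC)ccc1O` stands only at a limit, > 50000 nM. Compound 3 `COc1ccc(/C=C/C(=O)c2c(O)cc(O)cc2OC)cc1OC` gives 49500 nM, and compound 1 `COc1cc(O)c(CC=C(C)C)c(O)c1C(=O)/C=C/c1ccc(O)c(O)c1` gives 38100 nM. Compound 4 `COc1cc(O)cc(O)c1C(=O)/C=C/c1ccc(O)c(O)c1` differs from compound 2 by a single change, hydrogen in place of methyl on an oxygen on an aromatic ring. For the measured compounds named here, the one measured step of this kind runs the opposite way, with methyl in place of hydrogen on such an oxygen: a number no higher from compound 2 to compound 3 (the limit leaves the size open). As far as these compounds go, its size stays open, so compound 3 offers only a weak guide. No large move is expected, and an at least 1.1-fold lower number from compound 2 to compound 4 (0.04 log units; that floor lies within the scatter) is expected to stay within the scatter. For compound 4 the estimate is 45000 nM, with an expected range from 20000 nM to 90000 nM.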

Compound 4, half-maximal inhibitory concentration: 21300 nM
Beside the measured number, compound 4's estimate is 2.1-fold (0.32 log units) above it; the range from low to high includes it.
By their numbers in this assay, from the lowest: compounds 4, 1 and 3 (each within the scatter of the next, the first and the last beyond it). At a limit, above all of these: compound 2.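

Unlike the earlier step, methoxy to hydroxy on this aromatic ring has a readable floor: an at least 2.3-fold lower number from compound 2 to compound 4 (0.37 log units; beyond the scatter). Compound 2 stands only at a limit, so that floor does not fix the full size of the step: the limit of > 50000 nM in this assay, at which 1 of the 4 values shown sits. Hydrogen in place of 3-methylbut-2-en-1-yl on an aromatic carbon gives a 1.8-fold lower number from compound 1 to compound 4 (0.25 log units; within the scatter), so compound 4 keeps its inhibition in this assay without that chain. The compounds shown leave open how far the step from the limit really runs. They also leave open what an ethyl or a carboxymethyl group on this oxygen would do.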